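A few compounds are considered here, and "the series" means these few. Any claim that something is new, unique, unknown or untested is made for them only; others in the source may bear on it.

Compound 1 `Cc1ccc(C(=O)Nc2cccc(C(F)(F)F)c2)cc1-c1ccc2c(-c3cnn(C)c3)n[nH]c2c1`: 1870 nM
Compound 2 `Cc1ccc(C(=O)Nc2cccc(C(F)(F)F)c2)cc1-c1ccc2c(-c3cnn(C4CC4)c3)n[nH]c2c1`: 2240 nM

In an ADME assay on the whole organism (Mus musculus, strain ICR(CD-1)) for pharmacokinetics, read by mass spectrometry, at a dose of 10 mg/kg by the oral route (on this read-out lower numbers stand for lower exposure and higher numbers for higher exposure at the dose given), compound 2 gives 2240 nM, which lies within the scatter of compound 1 at 1870 nM. The two compounds therefore cannot be ranked on this read-out. Within the data shown here, only one measured step is available: a 1.2-fold higher number from compound 1 to compound 2 (0.08 log units; within the scatter), made by placing cyclopropyl in place of methyl on an aromatic nitrogen.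

The next compound, compound 3 `Cc1ccc(C(=O)Nc2cc(CN3CCN(C)CC3)cc(C(F)(F)F)c2)cc1-c1ccc2c(-c3cnn(C4CC4)c3)n[nH]c2c1`, changes a different part of the molecule. It has (4-methylpiperazin-1-yl)methyl in place of hydrogen on an aromatic carbon, meta to a trifluoromethyl group: (4-methylpiperazin-1-yl)methyl in place of hydrogen on an aromatic carbon. Among the measured compounds shown here, this is a much bigger alteration than swapping one small group for another, and no measured step covers it. The small step of a 1.2-fold higher number from compound 1 to compound 2 (0.08 log units; within the scatter) therefore says little about the size of this one, so any forecast must stay cautious and its range wide. A fall in this assay seems more likely than a rise, though no change at all remains possible. The expected shift is a 2.8-fold lower number from compound 2 to compound 3 (0.45 log units; beyond the scatter). For compound 3 the estimated value is 800 nM, with an expected range from 250 nM to 2500 nM.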

Compound 3, maximal plasma concentration in the Mus musculus assay: 181 nM
The estimate for compound 3 lay 4.4-fold (0.65 log units) above the measured number; measured number outside the range, below it.
By their numbers in the Mus musculus assay, from the lowest: compound 3; then compounds 1 and 2 (each within the scatter of the next).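

The aromatic carbon meta to a trifluoromethyl group is clearly sensitive to change. In the Mus musculus assay, placing (4-methylpiperazin-1-yl)methyl there gives a 12-fold lower number from compound 2 to compound 3 (1.09 log units; beyond the scatter), whereas the earlier change on the aromatic nitrogen gave only a 1.2-fold higher number from compound 1 to compound 2 (0.08 log units; within the scatter), which lies within the scatter. In a physicochemical assay for solubility (a lower number here means a less soluble compound, a higher number a more soluble compound), compound 2 gives 2000 nM and compound 3 gives 10000 nM. The same change thus moves the number the other way, so a loss of solubility cannot account for the fall in exposure, because solubility rose: the measured solubility of compound 2, 2000 nM, and of compound 3, 10000 nM, a 5.0-fold higher number (0.70 log units; beyond the scatter)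

From the compounds shown here alone, what caused the fall therefore stays unknown, as a maximal plasma concentration from a single pair of compounds does not show it. Going by these compounds, it also remains open whether the fall belongs to the whole (4-methylpiperazin-1-yl)methyl group or to one part of it, a question that a morpholin-4-ylmethyl group or a simple dimethylaminomethyl group at the same place would help to settle.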